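From a Phenethyl Arm to a Chlorobenzyl Arm

The compounds below may be only part of what the source reports. "The series", "measured", "known", "first", "only" and "open" are said of these compounds alone.

Compound 1 `Cc1ccc(-c2nc(N)c3cc(-c4ccccc4)sc3n2)o1`: 520 nM
Compound 2 `Cc1ccc(-c2nc(N)c3cc(CCc4ccccc4)sc3n2)o1`: 2780 nM
Compound 3 `COc1ccccc1Cc1cc2c(N)nc(-c3ccc(C)o3)nc2s1`: 122 nM

In a functional assay on CHO-K1 cells for antagonist activity at adenosine receptor A1 (Homo sapiens), read by a beta-galactosidase reporter and cAMP accumulation, with stated times of 15 min and 6 h (on this read-out higher numbers stand for weaker inhibition and lower numbers for stronger inhibition), compound 2 stands highest of the three numbers, meaning the weakest inhibition seen so far. The step of a 5.3-fold higher number from compound 1 to compound 2 (0.73 log units; beyond the scatter) raised the number, and the step of a 23-fold lower number from compound 2 to compound 3 (1.36 log units; beyond the scatter) brought it far down again.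

Compound 4 `Cc1ccc(-c2nc(N)c3cc(Cc4ccccc4Cl)sc3n2)o1` has not been measured yet. It differs from compound 2 by 2-chlorophenyl in place of benzyl on a saturated chain carbon bound to an aromatic carbon. Within the data shown here, only one measured step bears on this change: a 23-fold lower number from compound 2 to compound 3 (1.36 log units; beyond the scatter), a large drop, in which benzyl on the same saturated chain carbon also gave way to a substituted phenyl. A drop of similar size is therefore expected, a 15-fold lower number from compound 2 to compound 4 (1.19 log units; beyond the scatter). For compound 4 the estimated value is 180 nM, with a range from 60 nM to 550 nM.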

Compound 4, inhibition constant: 26.1 nM
Beside the measured number, compound 4's estimate is 6.9-fold (0.84 log units) above it; measured number outside the range, below it.
By their numbers in this assay, from the lowest: compound 4; then compound 3; then compound 1; then compound 2.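

In this assay the 2-chlorobenzyl arm gives the strongest inhibition of these four compounds, with a 110-fold lower number from compound 2 to compound 4 (2.03 log units; beyond the scatter) and a 20-fold lower number from compound 1 to compound 4 (1.30 log units; beyond the scatter) in the two comparisons with the other arms. The group on the arm's ring also counts, as chloro in place of methoxy gives a 4.7-fold lower number from compound 3 to compound 4 (0.67 log units; beyond the scatter) while the rest of the structure stays the same. No measurement here explains these differences.

Still open, on these data alone, is how bromo, fluoro or trifluoromethyl would compare with chloro on this ring. Whether an amine there would keep this level of inhibition is also unknown.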